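Swapping the halogenated ring on the thioether arm

The source may hold more compounds than are shown below. What is called first, only, known or untested is meant among the compounds shown, and "the series" means these compounds.

Compound 1, `C#CCNC1CCc2c(SCc3cccc(Cl)c3)cccc21`, is characterised in an ADME assay on isolated protein for inhibition of Amine oxidase [flavin-containing] B (Homo sapiens) (on this read-out higher numbers stand for weaker inhibition and lower numbers for stronger inhibition), where compound 1 gives 1090 nM. Compound 3, `C#CCNC1CCc2c(SCc3ccc(F)cc3F)cccc21`, gives 1480 nM in this assay, a number that lies within the scatter of compound 1. Compound 2, `C#CCNC1CCc2c(SCCc3cccc(OC)c3)cccc21`, gives 3820 nM, a higher number than compound 1 and beyond the scatter. Compound 1 thus stands at the lowest of the three numbers, though it cannot be separated from compound 3. Compound 4, `C#CCNC1CCc2c(SCc3ccc(Br)cc3)cccc21`, has not yet been measured and differs from compound 1 by 4-bromophenyl in place of 3-chlorophenyl on a saturated chain carbon bound to a sulfur. Because compound 3 gives 1480 nM with a different halogen pattern and still sits close to compound 1, the expected step of a 1.2-fold higher number from compound 1 to compound 4 (0.08 log units; within the scatter) is none beyond the scatter. Compound 4 is estimated at 1300 nM, within a range from 500 nM to 3500 nM.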

Compound 4, half-maximal inhibitory concentration: 488 nM
Beside the measured number, compound 4's estimate is 2.7-fold (0.43 log units) above it; the whole stated range lies above it.
By their numbers in this assay, from the lowest: compound 4; then compounds 1 and 3 (each within the scatter of the next); then compound 2.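

In this assay, 4-bromophenyl in place of 3-chlorophenyl on a saturated chain carbon bound to a sulfur gives (a 2.2-fold lower number from compound 1 to compound 4 (0.35 log units; beyond the scatter)), showing that this position responds to a swap between two halogenated rings of equal heavy-atom count. The halogen and its place on the ring change together, so this single step cannot be assigned to either one. No measurement offered here accounts for the step.

Still open, from the compounds shown here alone, is how 4-chlorophenyl or 3-bromophenyl would stand in this assay, which would separate the two changes, and whether an amine on this ring would be tolerated.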